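This account rests on a few compounds, and the source may have more. Where it says the series, first, only, none or still open, it means among the compounds named here.

Compound 1, `O=C(N/N=C/c1ccccc1)c1cccnc1`, in an ADME assay on HEL cells (Homo sapiens) for cytotoxicity, read by microscopy (on this read-out higher numbers stand for lower toxicity in this test and lower numbers for higher toxicity in this test), gives > 100 ug/mL, a limit of the assay and not a number.
Compound 2, `O=C(N/N=C/c1cccc(Br)c1)c1cccnc1`, in this assay gives > 100 ug/mL, again a limit of the assay and not a number.

Compound 2 therefore stands at the limit of this assay, as does every value shown so far: the limit of > 100 ug/mL in this assay, at which 2 of the 2 values shown sit. The next compound in the series is compound 3, `O=C(N/N=C/c1cccc(O)c1)c1cccnc1`. It differs from compound 2 in one place, (hydroxy in place of bromo on an aromatic carbon).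

For the measured compounds named here, only one measured step exists to compare with it, a step that the two limits leave unreadable from compound 1 to compound 2, and that step is unreadable because both ends sit at the limit. No readable step bears on the change to compound 3, so no shift beyond the scatter is expected, and the likeliest outcome is a further limit rather than a number. Compound 3 is expected at 100 ug/mL in this assay, within 50 ug/mL to 200 ug/mL. The step of a number no higher from compound 2 to compound 3 (the limit leaves the size open) is thus expected to be none beyond the scatter.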

Compound 3, minimum cytotoxic concentration: > 100 ug/mL
Compound 3: no number, only a limit; the forecaster's own chance of this, stated with the estimate: 80%; the middle value lies on the limit itself.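

Compound 1, compound 2 and compound 3 each give only a limit of the assay and not a number, so no step among them can be read in this assay: the limit of > 100 ug/mL in this assay, at which 3 of the 3 values shown sit.

The compounds shown leave open how far each lies past that limit, and whether bromo, hydroxy and hydrogen differ at all on this read-out.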